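A few compounds are considered here, and "the series" means these few. Any claim that something is new, unique, unknown or untested is made for them only; others in the source may bear on it.

Compound 1, `O=C(CC1CCCCC1)N1CCN(c2nc(=O)c3cc(C(F)(F)F)cc([N+](=O)[O-])c3s2)CC1`: 0.12 ug/mL
Compound 2, `Cc1ccc(C(=O)N2CCN(c3nc(=O)c4cc(C(F)(F)F)cc([N+](=O)[O-])c4s3)CC2)cc1`: 6.7 ug/mL
Compound 3, `CC(C)CC(=O)N1CCN(c2nc(=O)c3cc(C(F)(F)F)cc([N+](=O)[O-])c3s2)CC1`: 66.3 ug/mL

All three share one core and differ only in the group on the carbonyl carbon of the amide. In a physicochemical assay for solubility, read by HPLC (on this read-out higher numbers stand for higher solubility and lower numbers for lower solubility), compound 2 stands second highest of the three; its nearest neighbour is reached by a 9.9-fold higher number from compound 2 to compound 3 (1.00 log units; beyond the scatter), the furthest by a 56-fold higher number from compound 1 to compound 2 (1.75 log units; beyond the scatter).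

Compound 4, `CCCC(=O)N1CCN(c2nc(=O)c3cc(C(F)(F)F)cc([N+](=O)[O-])c3s2)CC1`, has not yet been measured. Its change from compound 2 is propyl in place of 4-methylphenyl on a carbonyl carbon. The step that bears most directly on it is a 9.9-fold higher number from compound 2 to compound 3 (1.00 log units; beyond the scatter), where the same aromatic group gave way to a short chain of four carbons; the present change brings an even shorter chain. The step of a 550-fold higher number from compound 1 to compound 3 (2.74 log units; beyond the scatter) shows that a smaller saturated group also went with a much higher number. A modest to large rise is therefore expected. Compound 4 is expected to show a 15-fold higher number from compound 2 to compound 4 (1.17 log units; beyond the scatter), an estimated 100 ug/mL, within a range from 25 ug/mL to 350 ug/mL.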

Compound 4, solubility: 2.46 ug/mL
Beside the measured number, compound 4's estimate is 41-fold (1.61 log units) above it, outside the stated range (below it).
By their numbers in this assay, from the lowest: compound 1; then compound 4; then compound 2; then compound 3.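

In this assay the move from 4-methylphenyl to propyl on the carbonyl carbon gives a 2.7-fold lower number from compound 2 to compound 4 (0.44 log units; beyond the scatter) and so lowers the number, which shows that a saturated chain in place of the aromatic ring does not raise it on its own. Hydrogen in place of a single methyl on the chain gives a 27-fold lower number from compound 3 to compound 4 (1.43 log units; beyond the scatter) as a large drop from a very small edit, while a 21-fold higher number from compound 1 to compound 4 (1.31 log units; beyond the scatter) still shows a large rise when ethyl replaces cyclohexyl. How a longer straight chain, or a chain carrying an amine or a carboxylic acid, would read at this position remains open, and no measurement shown accounts for these steps.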